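Swapping a Benzyl for a Methoxyphenyl on the Core

The source may hold more compounds than are shown below. What is called first, only, known or untested is meant among the compounds shown, and "the series" means these compounds.

In an ADME assay on HepG2 cells (Homo sapiens) for cytotoxicity, read by luminescence, CellTiter-Glo and ATP content, with a stated time of 72 h (on this read-out higher numbers stand for an effect only at larger amounts of compound and lower numbers for an effect already at smaller amounts), compound 1 `Cc1cc(C)cc(Cc2ccc3c(NCCCNCc4ccco4)ccnc3c2)c1` gives 6270 nM. Compound 2 `COc1cccc(CNCCCNc2ccnc3cc(-c4ccc(F)cc4)ccc23)c1O` gives 6840 nM in this assay, a number within the scatter of that of compound 1, so the two cannot be told apart. Compound 3 `COc1cccc(CNCCCNc2ccnc3cc(Cc4cc(C)cc(C)c4)ccc23)c1O` gives 2680 nM, and the step from compound 1 is a 2.3-fold lower number from compound 1 to compound 3 (0.37 log units; beyond the scatter). Compound 4 `COc1ccc(-c2ccc3c(NCCCNCc4ccco4)ccnc3c2)cc1` has not been measured; it differs from compound 1 in one place: 4-methoxyphenyl in place of 3,5-dimethylbenzyl on an aromatic carbon. Going by the values given here, no measured step makes exactly this change. The closest is a 2.6-fold lower number from compound 2 to compound 3 (0.41 log units; beyond the scatter), where 3,5-dimethylbenzyl took the place of 4-fluorophenyl and the number fell. Compound 4 makes the opposite kind of change, a group bound straight to the core replacing 3,5-dimethylbenzyl, though the entering group differs from 4-fluorophenyl, so the expected step is a rise of similar modest size, a 1.9-fold higher number from compound 1 to compound 4 (0.28 log units; within the scatter). Compound 4 is therefore estimated at 12000 nM in this assay, with a range from 5000 nM to 30000 nM.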

Compound 4, half-maximal effective concentration: 6000 nM
Compound 4: the middle estimate sits 2.0-fold (0.30 log units) above what was measured; low and high end bracket the measured number.
By their numbers in this assay, from the lowest: compound 3; then compounds 4, 1 and 2 (each within the scatter of the next).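

At this aromatic carbon of the shared core, with the furan-2-yl side chain in place, the change to 4-methoxyphenyl gives a 1.0-fold lower number from compound 1 to compound 4 (0.02 log units; within the scatter), so 3,5-dimethylbenzyl and 4-methoxyphenyl cannot be told apart in this assay. The earlier swap at this position, made with the 2-hydroxy-3-methoxyphenyl side chain and a different leaving group, gave a 2.6-fold lower number from compound 2 to compound 3 (0.41 log units; beyond the scatter), so a change here does not always move the number beyond the scatter. Nothing available explains why these two swaps read differently.

Going by these compounds, it remains open how 4-methoxyphenyl would read alongside the 2-hydroxy-3-methoxyphenyl side chain, a pairing that would show whether the side chain shapes the outcome at this position. Also open, on these data alone, is how a carboxylic acid or a morpholine on this aromatic carbon would read.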